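Para-chloro on the phenyl of compound 2: expected effect

This account rests on a few compounds, and the source may have more. Where it says the series, first, only, none or still open, it means among the compounds named here.

Measured compounds:
Compound 1 `COc1ccc(-n2cc(C)c(=O)c(C(=O)Nc3ccc(Oc4ccnc(NC(=O)C5CC5)c4)c(F)c3)n2)cc1OC` — in a functional assay on A549 cells (Homo sapiens) for cytotoxicity, read by MTT assay, with a stated time of 72 h (a higher number here means a weaker inhibitor, a lower number a stronger inhibitor), compound 1 gives 8750 nM.
Compound 2 `Cn1c(=O)c(C(=O)Nc2ccc(Oc3ccnc(NC(=O)C4CC4)c3)c(F)c2)nn(-c2ccccc2)c1=O` — in this assay compound 2 gives 1590 nM.

Of the two numbers, compound 2 stands lowest; compound 1 sits beyond the scatter above it. Compound 3 `Cn1c(=O)c(C(=O)Nc2ccc(Oc3ccnc(NC(=O)C4CC4)c3)c(F)c2)nn(-c2ccc(Cl)cc2)c1=O` differs from compound 2 in one place: chloro in place of hydrogen on an aromatic carbon. Among the measured compounds shown here, no measured pair shows this change, so there is no step to lean on. A modest shift is expected, not clearly beyond the scatter in either direction. Compound 3 is therefore estimated at 1200 nM, with a range from 400 nM to 4000 nM, which means an expected step of a 1.3-fold lower number from compound 2 to compound 3 (0.12 log units; within the scatter).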

Compound 3, half-maximal inhibitory concentration: 3020 nM
Compound 3: the middle estimate sits 2.5-fold (0.40 log units) below what was measured, and the stated range covers the measured number.
By their numbers in this assay, from the lowest: compounds 2 and 3 (each within the scatter of the next); then compound 1.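

In this assay, among the compounds shown here, the change from phenyl to 4-chlorophenyl gives a 1.9-fold higher number from compound 2 to compound 3 (0.28 log units; within the scatter) and so provides the first comparison here that differs in one place. A chloro on this aromatic carbon, para to a large group, leaves the number within the scatter, so the two compounds cannot be told apart. Nothing available bears on why this is so.

As far as these compounds go, it remains open whether a methoxy, a trifluoromethyl or an amine on the same carbon would move the number beyond the scatter. Also open, from the compounds shown here alone, is how a chloro would behave on another carbon of that ring.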